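The compounds below may be only part of what the source reports. "The series", "measured", "known", "first", "only" and "open" are said of these compounds alone.

In an assay on CHO cells for displacement of a labelled ligand from adenosine receptor A3 (Homo sapiens) (on this read-out higher numbers stand for weaker inhibition and lower numbers for stronger inhibition), compound 3 (`CNc1ncc(C(=O)O)c2nc(-c3ccco3)nn12`) gives 15900 nM, the second highest of the three numbers recorded. Compound 1 (`CNC(=O)c1cnc(NC(=O)NC2CCCCC2)n2nc(-c3ccco3)nc12`) gives 18700 nM in this assay, a number within the usual scatter of that of compound 3, so the two cannot be ordered. Compound 2 (`CCOC(=O)c1cnc(NCC2CCCCC2)n2nc(-c3ccco3)nc12`) gives 41.2 nM, a far lower number that lies well beyond the scatter. Compound 4 (`CCCCC(CC)CNc1ncc(C(=O)O)c2nc(-c3ccco3)nn12`) differs from compound 3 in one place: 1-ethylpentyl in place of hydrogen on a saturated chain carbon bound to a nitrogen on an aromatic ring. Going by the values given here, no measured pair shows this change alone, so its effect must be guessed. A moderate move toward a lower number is expected, the step being a 5.3-fold lower number from compound 3 to compound 4 (0.72 log units; beyond the scatter). Compound 4 is therefore estimated at 3000 nM, with a range from 500 nM to 20000 nM.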

Compound 4, inhibition constant: 16400 nM
The estimate for compound 4 lay 5.5-fold (0.74 log units) below the measured number, and the stated range covers the measured number.
By their numbers in this assay, from the lowest: compound 2; then compounds 3, 4 and 1 (each within the scatter of the next).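

In this assay, putting 1-ethylpentyl in place of hydrogen on a saturated chain carbon bound to a nitrogen on an aromatic ring gives a 1.0-fold higher number from compound 3 to compound 4 (0.01 log units; within the scatter). With the carboxylic acid kept, this place therefore takes methyl and 2-ethylhexyl with no difference that can be read in this assay. Nothing available here explains this result. Still open, going by these compounds, is whether a propyl chain or a benzyl group at this place would give a number apart from these two. On these data alone, an amine at the end of the chain is equally open.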